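Ester variation on the shared core at the adenosine receptor

The source may hold more compounds than are shown below. What is called first, only, known or untested is meant among the compounds shown, and "the series" means these compounds.

Measured compounds:
compound 1, `CC1=C(C(=O)OC(C)(C)C)C(c2ccsc2)NC(=O)N1`: 15%
compound 2, `CCCOC(=O)C1=C(C)N(C)C(=O)NC1c1ccco1`: 3%

In an assay on membranes from CHO cells for displacement of a labelled ligand from adenosine receptor A1 (Homo sapiens), read by scintillation counting, with a stated time of 60 min, tested at 1 uM (on this read-out higher numbers stand for more inhibition at the one concentration tested (going by the name of the read-out) and lower numbers for less inhibition), compound 1 gives 15% and compound 2 gives 3%. Compound 2 stands lowest of the two numbers; its nearest neighbour is compound 1, which lies higher by a gap that is beyond the scatter. Among the compounds with values here, compound 1 and compound 2 differ in more than one place, so no single step between them can be read off.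

The step followed here goes from compound 2 to compound 3, `CC1=C(C(=O)OC(C)(C)C)C(c2ccco2)NC(=O)N1C`, not yet measured in this assay. The change is tert-butyl in place of propyl on an oxygen next to a carbonyl group. Within the data shown here, it is a small change in a chain on the ester oxygen; no pair of measured compounds isolates this change, so no step in this assay is available to lean on. The expectation is that the step of a number 5 percentage points higher from compound 2 to compound 3 (within the scatter) stays within the scatter, tending slightly upward. Compound 3 is therefore estimated at 8%, with a range from -5% to 25%.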

Compound 3, a percentage reported as inhibition, at one concentration (the size of the read-out at that concentration, not a potency): 44%
Compound 3: the middle estimate sits 36 percentage points below what was measured, outside the stated range (above it).
By their numbers in this assay, from the lowest: compound 2; then compound 1; then compound 3.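

In this assay, within the data shown here, this place on the shared core proves responsive: tert-butyl in place of propyl on an oxygen next to a carbonyl group comes with a number 41 percentage points higher from compound 2 to compound 3 (beyond the scatter), a large step and the only single-place step so far. The change is small by count, with 3 heavy atoms leaving and 4 entering, and neither group brings a ring, a hydrogen-bond donor, a hydrogen-bond acceptor or a net charge. No measurement at hand accounts for the size of this step.

Compound 1 also carries tert-butyl here but differs from compound 3 in more than one place, so it cannot show whether the step holds with other groups elsewhere on the core. The compounds shown also leave open how isopropyl, a longer chain such as hexyl, or a carboxylic acid in place of the ester would read.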